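The compounds below may be only part of what the source reports. "The series", "measured", "known", "first", "only" and "open" are said of these compounds alone.

Measured so far:
compound 1, `O=C(CNC(=O)c1nn(-c2ccccc2)c(=O)c2ccccc12)Nc1nc2ccc(F)cc2s1`: 470 nM
compound 2, `O=C(CNC(=O)c1nn(-c2ccccc2)c(=O)c2ccccc12)Nc1nccs1`: > 25000 nM
compound 3, `COc1ccc(-n2c(SCC(=O)Nc3nc4ccc(Cl)cc4s3)nc3c(c2=O)SCC3)cc1`: 35 nM

In an assay on L cells for inhibition of Protein-serine O-palmitoleoyltransferase porcupine (Mus musculus), read by reporter gene assay, with a stated time of 24 h (on this read-out higher numbers stand for an effect only at larger amounts of compound and lower numbers for an effect already at smaller amounts), compound 1 gives 470 nM, the highest of the two numbers shown. Compound 3 gives 35 nM, a lower number. For compound 2 the assay reports only a limit, (the limit of > 25000 nM in this assay, at which 1 of the 3 values shown sits). Among the compounds with values here, the one measured step, an at least 53-fold higher number from compound 1 to compound 2 (1.72 log units; beyond the scatter), changes a different part of the shared core. Compound 4, `O=C(CNC(=O)c1nn(-c2ccccc2)c(=O)c2ccccc12)Nc1nc2ccc(C(F)(F)F)cc2s1`, instead differs from compound 1 by trifluoromethyl in place of fluoro on an aromatic carbon. Within the data shown here, no measured step touches this group, so a change within the usual scatter is expected. The estimated step is a 1.1-fold higher number from compound 1 to compound 4 (0.03 log units; within the scatter). Compound 4 is therefore expected to give 500 nM, with a range from 150 nM to 1800 nM.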

Compound 4, half-maximal effective concentration: 110 nM
Compound 4: the middle estimate sits 4.5-fold (0.66 log units) above what was measured, outside the stated range (below it).
By their numbers in this assay, from the lowest: compound 3; then compound 4; then compound 1. At a limit, above all of these: compound 2.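

In this assay, the group on this aromatic carbon matters: trifluoromethyl in place of fluoro gives a 4.3-fold lower number from compound 1 to compound 4 (0.63 log units; beyond the scatter). The earlier step exchanged the whole group on the amide-type nitrogen, whereas this one shows that changing a single substituent, with the rest of compound 1 kept, already moves the number beyond the scatter. The compounds shown give no reason for this shift. From the compounds shown here alone, with only fluoro and trifluoromethyl compared here, it stays open how a nitrile, a methoxy group or an amine on this carbon would read. Going by these compounds, it also stays open whether the same exchange would give a similar step on another core.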